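Acetylation of a Flavone Hydroxy Group and B16 Cytotoxicity

This account rests on a few compounds, and the source may have more. Where it says the series, first, only, none or still open, it means among the compounds named here.

Compound 1 `COc1c(O)c(OC)c2oc(-c3ccc(O)cc3)c(OC)c(=O)c2c1O`: > 100000 nM
Compound 2 `CC(=O)Oc1ccc(-c2oc3cc(OC(C)=O)cc(O)c3c(=O)c2OC(C)=O)cc1`: 39800 nM

Going by the values given here, in an ADME assay on B16 cells (Mus musculus) for cytotoxicity, read by MTT assay, with a stated time of 48 h (a higher number here means a weaker inhibitor, a lower number a stronger inhibitor), compound 2 gives 39800 nM, the only number among the two values shown. For compound 1 the assay reports only a limit, (the limit of > 100000 nM in this assay, at which 1 of the 2 values shown sits), not a number. Compound 3 `CC(=O)Oc1ccc(-c2oc3cc(OC(C)=O)cc(OC(C)=O)c3c(=O)c2OC(C)=O)cc1` differs from compound 2 by acetyl in place of hydrogen on an oxygen on an aromatic ring. Among the compounds with values here, no pair of measured compounds differing in one place is available, so no measured step guides this change. Compound 3 is expected to sit close to compound 2, with the step of a 1.3-fold lower number from compound 2 to compound 3 (0.12 log units; within the scatter) likely within the scatter. Compound 3 is estimated at 30000 nM, between 10000 nM and 100000 nM.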

Compound 3, half-maximal inhibitory concentration: 40700 nM
For compound 3 the middle estimate is 1.4-fold (0.13 log units) below the measured one; measured number inside the range.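

In this assay, going by these compounds alone, the change from hydroxy to acetoxy on an oxygen on an aromatic ring is the first measured step at this position (a 1.0-fold higher number from compound 2 to compound 3 (0.01 log units; within the scatter)). Compound 2 and compound 3 therefore stand within the scatter of each other, and at this position the acetyl group in place of hydrogen leaves no readable difference. No measurement shown bears on why this is so. The compounds shown leave open whether a longer acyl chain or an amine-bearing group on this oxygen would also stay within the scatter of compound 2.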